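Thiocarbonyl amine swap in a pyridyl amidrazone series

The source may hold more compounds than are shown below. What is called first, only, known or untested is meant among the compounds shown, and "the series" means these compounds.

Compound 1 `Cc1cccc(/C(N)=N/NC(=S)N2CCN(c3ccccn3)CC2)n1`: 43%
Compound 2 `N/C(=N\NC(=S)N1CCN(c2ccccn2)CC1)c1ccc(F)cn1`: 47.4%
Compound 3 `Cc1ccnc(/C(N)=N/NC(=S)N2CCSCC2)c1`: 60%

In a functional assay on A-431 cells (Homo sapiens) for cytotoxicity, read by MTT assay, with a stated time of 72 h, tested at 10 uM (on this read-out lower numbers stand for less inhibition of growth and higher numbers for more inhibition of growth at the one concentration tested), compound 3 gives the highest of the three numbers, and both compound 2 and compound 1 lie below it by more than the usual scatter. Compound 4 `Cc1ccnc(/C(N)=N/NC(=S)N2CCCC2)c1` differs from compound 3 by pyrrolidin-1-yl in place of thiomorpholin-4-yl on a thiocarbonyl carbon. Within the data shown here, the only measured step, a number 4.4 percentage points higher from compound 1 to compound 2 (within the scatter), alters the group on the carbon with a double bond to nitrogen and leaves the thiocarbonyl side untouched, so no measured step bears on the present change. For compound 4 the expected change is a number 5 percentage points lower from compound 3 to compound 4 (within the scatter), that is, nothing beyond the scatter. The estimate for compound 4 is 55%, expected to fall between 35% and 75%.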

Compound 4, percent growth inhibition at one concentration: 71.2%
For compound 4 the middle estimate is 16.2 percentage points below the measured one; the measured number falls inside the stated range.
By their numbers in this assay, from the lowest: compounds 1 and 2 (each within the scatter of the next); then compound 3; then compound 4.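

With the shared core held constant, replacing thiomorpholin-4-yl with pyrrolidin-1-yl on the thiocarbonyl carbon gives, in this assay, a number 11.2 percentage points higher from compound 3 to compound 4 (beyond the scatter). Among these compounds, this shows that the group at this position can shift growth inhibition, which the only earlier step, made elsewhere in the molecule, could not show. Nothing shown accounts for the gain.

The change alters ring size and removes the ring sulfur together, so the compounds shown cannot separate the two. A piperidin-1-yl group on the same carbon would keep the six-membered ring without sulfur and so help to tell them apart.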